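The compounds below may be only part of what the source reports. "The series", "measured", "known", "first", "only" and "open" are said of these compounds alone.

Measured so far in a functional assay on LOX IMVI cells (Homo sapiens) for inhibition, read by sulforhodamine B assay, with a stated time of 48 h; on this read-out higher numbers stand for weaker inhibition of growth and lower numbers for stronger inhibition of growth:
compound 1 `CCOC(=O)[C@H](CCC(=O)O)NC(=O)c1ccc(Oc2nc3cc(N)cc(N)c3nc2-c2ccccc2)cc1` gives 26300 nM
compound 2 `Nc1cc(N)c2nc(-c3ccccc3)c(NCc3ccc(F)cc3)nc2c1` gives 3160 nM
compound 3 `COc1ccc(Sc2nc3cc(N)cc(N)c3nc2-c2ccccc2)cc1` gives < 100000 nM, which is a limit of the assay and not a number.

Compound 3 therefore stands nowhere on the number scale: its value is the one of the three that sits at the limit (the limit of < 100000 nM in this assay, at which 1 of the 3 values shown sits), and the step that the limit leaves unreadable from compound 2 to compound 3 cannot be read in size or in direction.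

The step to compound 4 `Nc1cc(N)c2nc(-c3ccccc3)c(Sc3ccc(F)cc3)nc2c1` is fluoro in place of methoxy on an aromatic carbon.

Among the measured compounds shown here, none of the measured steps bears on this change directly; no measured pair exchanges fluoro for methoxy, and the only step that touches compound 3 is unreadable. What remains is a rough frame from the other two compounds. Compound 2, which also carries fluoro on its pendant ring but with a different link to the shared core, gives 3160 nM in this assay. Compound 1, with an aryl ether link and a larger substituent, gives 26300 nM in this assay. Compound 4 is thus expected to fall somewhere between those two, most likely at 25000 nM, with a range from 3000 nM to 100000 nM. The expected step that the limit leaves unreadable from compound 3 to compound 4 cannot be set against the scatter, since compound 3 offers only a limit, and a limit rather than a number is also possible for compound 4.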

Compound 4, concentration for total growth inhibition: 40700 nM
Beside the measured number, compound 4's estimate is 1.6-fold (0.21 log units) below it; measured number inside the range.
By their numbers in this assay, from the lowest: compound 2; then compounds 1 and 4 (each within the scatter of the next).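

In this assay, (4-fluorophenyl)sulfanyl in place of (4-fluorobenzyl)amino on this aromatic carbon gives a 13-fold higher number from compound 2 to compound 4 (1.11 log units; beyond the scatter), so the group held at this position matters, and the size of the change lies beyond the scatter. Among the compounds shown here, compound 4 also gives the first number for a sulfanyl-linked compound, 40700 nM, where the earlier sulfanyl-linked compound offered no number to work from. Compound 3 gives < 100000 nM, which is a limit of the assay and not a number, so neither step that touches compound 3, including fluoro in place of methoxy on the ring, can be read in size or direction: the limit of < 100000 nM in this assay, at which 1 of the 4 values shown sits.

The step from compound 2 to compound 4 changes the linking atom and the methylene together, so a pair such as (4-fluorophenyl)amino and (4-fluorobenzyl)sulfanyl would be needed to tell which part carries the change. Also open, on these data alone, is how a chloro group, an amine or a carboxylic acid would read in place of fluoro on the sulfanyl-linked phenyl ring, since a second measured number there would give this ring a first readable step.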